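From 3-chlorophenyl to (pyridin-2-yl)methyl on one chain carbon

The source may hold more compounds than are shown below. What is called first, only, known or untested is meant among the compounds shown, and "the series" means these compounds.

Three compounds already have numbers in a functional assay on a cell-free system (plasma, Homo sapiens), with a stated time of 3 min (a higher number here means a weaker inhibitor, a lower number a stronger inhibitor), to anchor this comparison. Compound 1 (`O=C(NCc1cc(Cl)ccc1-n1cnnn1)[C@@H]1C[C@@H]2C[C@@H]2N1C(=O)[C@H](O)c1cccc(Cl)c1`) gives 1000 nM in this test. Compound 2 (`CC(C)(C)[C@@H](O)C(=O)N1OCC[C@H]1C(=O)NCc1cc(Cl)ccc1-n1cnnn1`) gives 1600 nM there, and compound 3 (`CC(C)(C)[C@@H](O)C(=O)N1CSC[C@H]1C(=O)NCc1cc(Cl)ccc1-n1cnnn1`) gives 1200 nM under the same conditions. Compound 1 therefore stands level with the other two, since all three numbers lie within the usual scatter of repeated measurements. No two of these compounds differ in only one place, so the data hold no direct measure of what a single swap does.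

Compound 4 (`O=C(NCc1cc(Cl)ccc1-n1cnnn1)[C@@H]1C[C@@H]2C[C@@H]2N1C(=O)[C@H](O)Cc1ccccn1`) has not yet been measured. It keeps the core of compound 1 but carries (pyridin-2-yl)methyl in place of 3-chlorophenyl on a saturated chain carbon bound to a carbonyl carbon and an oxygen on a saturated carbon. With no measured swap of this kind to lean on, the expectation is cautious and amounts to a judgement. The expected change is a 2.5-fold higher number from compound 1 to compound 4 (0.40 log units; beyond the scatter) in this assay as a modest move toward a higher number, which may not clear the scatter. For compound 4 the estimated value is 2500 nM with an expected range from 600 nM to 10000 nM once it is tested.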

Compound 4, half-maximal inhibitory concentration: 1000 nM
The estimate for compound 4 lay 2.5-fold (0.40 log units) above the measured number, and the stated range covers the measured number.
By their numbers in this assay, from the lowest: compounds 1, 4, 3 and 2 (each within the scatter of the next).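

In this assay, placing (pyridin-2-yl)methyl in place of 3-chlorophenyl on a saturated chain carbon bound to a carbonyl carbon and an oxygen on a saturated carbon gives no change at the digits printed from compound 1 to compound 4 (within the scatter). Among these compounds, this is the first direct reading of a single swap in this set, and it shows that this carbon can take a group with a ring nitrogen and a hydrogen-bond acceptor instead of a carbon-only ring bearing chlorine, with the number staying within the scatter. No measurement here explains this flat result, and a single step cannot show whether each part of the swap is without effect or whether the parts offset one another.

The swap changes the ring atoms, removes the chlorine and adds a methylene link all at once, so a plain phenyl or benzyl group at this carbon would be needed to tell these parts apart. As far as these compounds go, it also remains open whether a group of a different kind here, such as an amine, a carboxylic acid or a longer chain ending in the pyridine ring, would carry the number beyond the scatter.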